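Second trifluoromethyl on the urea aryl of compound 1

The compounds below may be only part of what the source reports. "The series", "measured", "known", "first", "only" and "open" are said of these compounds alone.

Compound 1 `O=C(Nc1cccc(-n2cc(-c3ccncc3)c(-c3ccc(Cl)c(O)c3)n2)c1)Nc1cccc(C(F)(F)F)c1` stands at the high end of the three numbers measured in a functional assay on SF-539 cells (Homo sapiens) for inhibition, read by sulforhodamine B assay, with a stated time of 48 h (a higher number here means a weaker inhibitor of growth, a lower number a stronger inhibitor of growth), giving 3540 nM. Compound 2 `O=C(Nc1cccc(-n2cc(-c3ccncc3)c(-c3ccc(Cl)c(O)c3)n2)c1)Nc1ccc(Cl)c(Cl)c1` gives 1340 nM, and the change from compound 1 is a 2.6-fold lower number from compound 1 to compound 2 (0.42 log units; beyond the scatter). Compound 3 `COc1cc(-c2nn(-c3cccc(NC(=O)Nc4cccc(C(F)(F)F)c4)c3)cc2-c2ccncc2)ccc1Cl` gives 890 nM, the change from compound 1 being a 4.0-fold lower number from compound 1 to compound 3 (0.60 log units; beyond the scatter).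

Compound 4 `O=C(Nc1cccc(-n2cc(-c3ccncc3)c(-c3ccc(Cl)c(O)c3)n2)c1)Nc1cc(C(F)(F)F)cc(C(F)(F)F)c1` differs from compound 1 by one change: trifluoromethyl in place of hydrogen on an aromatic carbon.

Among the measured compounds shown here, of the two measured steps, only the step from compound 1 to compound 2 touches the same urea aryl ring, and it replaced the whole substituent rather than adding a second group; the step from compound 1 to compound 3 lies on the other side of the shared core and does not bear on this ring. Both steps moved the number down by a modest amount. For the measured compounds named here, no measured pair shows the effect of a second trifluoromethyl on this ring, so the direction is open; the one relevant step leans towards a small lowering.

For compound 4 a modest step of a 1.4-fold lower number from compound 1 to compound 4 (0.15 log units; within the scatter) is expected in this assay , with an estimated value of 2500 nM, within 800 nM to 8000 nM.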

Compound 4, concentration for 50% growth inhibition: 765 nM
For compound 4 the middle estimate is 3.3-fold (0.51 log units) above the measured one, and the stated range ends above it.
By their numbers in this assay, from the lowest: compounds 4, 3 and 2 (each within the scatter of the next); then compound 1.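

In this assay, the step from hydrogen to trifluoromethyl on this aromatic carbon, meta to a trifluoromethyl group, gives a 4.6-fold lower number from compound 1 to compound 4 (0.67 log units; beyond the scatter). Among the compounds shown here, the earlier step on this ring, a 2.6-fold lower number from compound 1 to compound 2 (0.42 log units; beyond the scatter), exchanged the whole substituted aryl group, whereas this one keeps the original trifluoromethyl and adds a second, so it is the first direct reading at this position: the added group lowers the number, and the direction of the change is no longer open. Nothing measured on these compounds explains why the number falls with this change.

The compounds shown leave open whether the lowering is particular to trifluoromethyl or would also follow from a different group on the same carbon, such as a nitrile, an amine or a carboxylic acid. They also leave open whether the step carries over to the methyl ether of compound 3, where methyl stands in place of hydrogen on the oxygen, or whether the two changes together would lower the number further in this assay.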